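A few compounds are considered here, and "the series" means these few. Any claim that something is new, unique, unknown or untested is made for them only; others in the source may bear on it.

For the measured compounds named here, compound 1 `COc1ccccc1-c1nc2ccccc2[nH]1` is one of two compounds measured in a functional assay on the whole organism (ileum) with Rattus norvegicus as the target; on this read-out lower numbers stand for stronger inhibition and higher numbers for weaker inhibition. In this assay compound 1 gives 7700 nM. The other measured compound, compound 2 `Cc1ccc(COc2ccccc2-c2nc3ccccc3[nH]2)cc1`, gives 15000 nM in this assay, and the step of a 1.9-fold higher number from compound 1 to compound 2 (0.29 log units; within the scatter) lies within the scatter, so the two compounds are not told apart by these numbers. Compound 3 `O=[N+]([O-])c1ccccc1-c1nc2ccccc2[nH]1` differs from compound 1 by nitro in place of methoxy on an aromatic carbon. Going by the values given here, no measured step replaces a methoxy with a nitro anywhere in this set; the only measured step, a 1.9-fold higher number from compound 1 to compound 2 (0.29 log units; within the scatter), alters the chain on the oxygen rather than the group on the ring, and it stayed within the scatter. On that thin basis a step of a 1.0-fold higher number from compound 1 to compound 3 (0.02 log units; within the scatter) is expected, meaning no change beyond the scatter. For compound 3 the expected value in this assay is 8000 nM, with a range from 2500 nM to 25000 nM.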

Compound 3, half-maximal inhibitory concentration: 78600 nM
Compound 3: middle estimate off by 9.8-fold (0.99 log units), on the low side; the whole stated range lies below it.
By their numbers in this assay, from the lowest: compounds 1 and 2 (each within the scatter of the next); then compound 3.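

For the compounds shown here, the group on this aromatic carbon, ortho to a group of 9 heavy atoms, matters in this assay: nitro in place of methoxy gives a 10-fold higher number from compound 1 to compound 3 (1.01 log units; beyond the scatter), the first step in this set beyond the scatter, towards weaker inhibition. The earlier step, a 1.9-fold higher number from compound 1 to compound 2 (0.29 log units; within the scatter), kept the oxygen on the ring and stayed within the scatter, so at this carbon a 4-methylphenyl on the methoxy carbon left the number within the scatter, while replacing the whole methoxy with nitro did not. No measurement shown here accounts for the step.

From the compounds shown here alone, with only methoxy and nitro at this carbon, it stays open whether the step follows from losing methoxy or from gaining nitro, and an amine, a hydroxyl or a chlorine there could help separate the two. Going by these compounds, whether the same change at another carbon of that ring would give a similar step also stays open.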